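Replacement of the sulfur-linked bicycle in the urea series

The source may hold more compounds than are shown below. What is called first, only, known or untested is meant among the compounds shown, and "the series" means these compounds.

Within the data shown here, compound 2 `CCCCCCN(CCCCCSc1nc2cc([N+](=O)[O-])ccc2[nH]1)C(=O)Nc1ccc(F)cc1F` gives 2000 nM in an assay on microsomes from liver for inhibition of sterol O-acyltransferase 1 (Rattus norvegicus) (a lower number here means a stronger inhibitor, a higher number a weaker inhibitor), the lowest of the two numbers so far; compound 1 `CCCCCCN(CCCCCSc1nc2ccccc2o1)C(=O)Nc1ccc(F)cc1F` gives 51000 nM. Compound 3 `CCCCCCN(CCCCCSc1nc2c[nH]cnc-2n1)C(=O)Nc1ccc(F)cc1F` differs from compound 2 by a group of 9 heavy atoms (5 carbon, 4 nitrogen; one five-membered aromatic ring with 2 hetero atoms, one six-membered aromatic ring with 2 hetero atoms) in place of a group of 12 heavy atoms (7 carbon, 3 nitrogen, 2 oxygen; one five-membered aromatic ring with 2 hetero atoms, one six-membered aromatic ring of carbon only), on a sulfur. Among the measured compounds shown here, the only measured step at this position, a 26-fold lower number from compound 1 to compound 2 (1.41 log units; beyond the scatter), was large. The step to compound 3 is the reverse kind of exchange on the same sulfur, so a movement back toward the number of compound 1 is expected, though smaller than that step. Compound 3 is estimated at 12000 nM (range 3000 nM to 50000 nM), an expected step of a 6.0-fold higher number from compound 2 to compound 3 (0.78 log units; beyond the scatter).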

Compound 3, half-maximal inhibitory concentration: 860 nM
The estimate for compound 3 lay 14-fold (1.14 log units) above the measured number; the measured number lies below the stated range.
By their numbers in this assay, from the lowest: compound 3; then compound 2; then compound 1.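

In this assay, the position on the sulfur does not depend on a nitro group or on a six-membered aromatic ring of carbon only: the group with nitrogen in both rings gives a 2.3-fold lower number from compound 2 to compound 3 (0.37 log units; beyond the scatter). With a 59-fold lower number from compound 1 to compound 3 (1.77 log units; beyond the scatter), the range at this position widens, and compound 3 now marks its low end. No measured evidence accounts for either step. The compounds shown leave open whether both rings are needed, since a single imidazol-2-yl ring on the sulfur is not among them. Going by these compounds, whether an amino group in place of the nitro group on compound 2 would hold its number also remains open.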